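A few compounds are considered here, and "the series" means these few. Any claim that something is new, unique, unknown or untested is made for them only; others in the source may bear on it.

Among the compounds with values here, in an ADME assay on Vero cells (Chlorocebus sabaeus) for cytotoxicity, read by MTT assay, with a stated time of 72 h (a higher number here means that more compound is tolerated, a lower number that less compound is tolerated), compound 1 `COc1ccc([C@H](O)COC(=O)/C=C/c2ccccc2)cc1OC` gives 24300 nM, the higher of the two numbers measured so far. Compound 2 `COc1ccc([C@@H](O)COC(=O)/C=C/c2ccccc2)cc1OC` gives 5870 nM. Within the data shown here, this is the only measured step, a 4.1-fold lower number from compound 1 to compound 2 (0.62 log units; beyond the scatter), and it comes with the fact that compounds 1 and 2 differ only in the configuration as drawn. It shows that the compounds in this small set can move beyond the scatter, but it says nothing direct about adding a group.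

Compound 3 `COc1cc([C@H](O)COC(=O)/C=C/c2ccccc2)cc(OC)c1OC` keeps the configuration drawn for compound 1 and carries one structural change: methoxy in place of hydrogen on an aromatic carbon. Among the measured compounds shown here, no measured step covers such a change, so no direction is favoured. The estimated step, a 1.2-fold lower number from compound 1 to compound 3 (0.08 log units; within the scatter), is expected to stay within the scatter. For compound 3, the expected value is 20000 nM, with an estimated range from 7000 nM to 60000 nM.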

Compound 3, half-maximal cytotoxic concentration: 6440 nM
For compound 3 the middle estimate is 3.1-fold (0.49 log units) above the measured one; the measured number lies below the stated range.
By their numbers in this assay, from the lowest: compounds 2 and 3 (each within the scatter of the next); then compound 1.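

In this assay, a 3.8-fold lower number from compound 1 to compound 3 (0.58 log units; beyond the scatter) comes with a single methoxy in place of hydrogen, on an aromatic carbon ortho to a methoxy group and meta to a large group. Within the data shown here, this shows that the position responds: swapping a hydrogen for a group of 2 heavy atoms with no net charge moves the number beyond the scatter, whereas the earlier compounds showed such a move only with a change in configuration as drawn. The one fact at hand concerns configuration and offers no explanation for this methoxy step.

Open, as far as these compounds go, is whether this lower number belongs to methoxy itself or would also come with another group at this position, such as a hydroxyl, an amine or a fluorine. Also open, from the compounds shown here alone, is how the same methoxy would behave in the configuration of compound 2.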